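Carboxy for bromo on the aroyl ring: one precedent

The source may report more compounds than this note shows. Statements on the series, on what has been measured and on what is new or still open speak of the compounds shown alone.

Measured so far:
compound 1 `O=C(O)c1ccc(C(=O)/C(=C\c2ccc(O)c([N+](=O)[O-])c2)SCc2ccc(Br)cc2)cc1` — 50000 nM
compound 2 `O=C(/C(=C\c1ccc(O)c([N+](=O)[O-])c1)SCc1ccc(Br)cc1)c1ccc(Br)cc1` — 10000 nM
compound 3 `COc1ccc(/C=C(/SCc2ccc(Cl)cc2)C(=O)c2ccc(Br)cc2)cc1` — 10000 nM

In a functional assay on DU-145 cells (Homo sapiens) for inhibition, read by trypan blue exclusion, with a stated time of 96 h (on this read-out lower numbers stand for stronger inhibition of growth and higher numbers for weaker inhibition of growth), compound 2 gives 10000 nM and compound 3 gives 10000 nM; the two stand level at the digits given, and the difference between their cores is not broken down here. From compound 2 to compound 1 the change is carboxy in place of bromo on an aromatic carbon, and the resulting step is a 5.0-fold higher number from compound 2 to compound 1 (0.70 log units; beyond the scatter). Compound 4 `COc1ccc(/C=C(/SCc2ccc(Cl)cc2)C(=O)c2ccc(C(=O)O)cc2)cc1` has not yet been measured in this assay; it stands to compound 3 as carboxy in place of bromo on an aromatic carbon, the same change at the same place on the ring. Going by the values given here, for compound 4 the expected step is a 5.0-fold higher number from compound 3 to compound 4 (0.70 log units; beyond the scatter), because a 5.0-fold higher number from compound 2 to compound 1 (0.70 log units; beyond the scatter) is the only precedent and the two cores are level. Compound 4 is therefore expected to give about 50000 nM, with a range from 15000 nM to 150000 nM.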

Compound 4, concentration for 50% growth inhibition: 10000 nM
Compound 4: the middle estimate sits 5.0-fold (0.70 log units) above what was measured, outside the stated range (below it).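

In this assay, carboxy in place of bromo on an aromatic carbon gives no change at the digits printed from compound 3 to compound 4 (within the scatter), so the step seen on the core of compound 2 does not carry over to the core of compound 3. The two instances of the same change disagree: the same change on two cores in this assay, a 5.0-fold higher number (0.70 log units; beyond the scatter) from compound 2 to compound 1 and no change at the digits printed (within the scatter) from compound 3 to compound 4, 5.0-fold (0.70 log units) apart, beyond the scatter of two such steps. This shows that, on these two cores, one step cannot be used to estimate the other; it does not show which difference between the cores accounts for the gap, and two instances establish no rule for the series.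

Which part of the core sets the size of the step remains open. Also open, as far as these compounds go, is how a primary amide or a tetrazole in place of the bromo would read on each core.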